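The source may hold more compounds than are shown below. What is called first, only, known or untested is meant among the compounds shown, and "the series" means these compounds.

Compound 2 `CC1=NC(C)=C([N+](=O)[O-])C(c2ccncc2)/C1=C(\O)OC1CCCC1` holds the lower of the two numbers measured in a functional assay (cardiac atrium) for agonist activity, with Cavia porcellus as the target; a lower number here means that less compound is needed, a higher number that more compound is needed for the effect: in this assay compound 2 gives 4250 nM. For the measured compounds named here, the only comparator, compound 1 `CC1=NC(C)=C([N+](=O)[O-])C(c2ccccn2)/C1=C(\O)OC(C)(C)C`, differs from it in more than one place, so no single step can be drawn between the two; in this assay compound 1 gives 1810000 nM, a far higher number that lies well beyond the scatter. Compound 3 `CCO/C(O)=C1\C(C)=NC(C)=C([N+](=O)[O-])C1c1ccncc1` has not yet been measured in this assay. It differs from compound 2 in a single place: ethyl in place of cyclopentyl on an oxygen on an unsaturated carbon. Going by the values given here, no measured pair isolates this kind of change, so the size of the step cannot be read from the numbers in hand. Compound 2 carries the larger of the two ester groups seen here and also the lowest number, but with compound 1 differing elsewhere as well, that single value supports no pattern. The expectation is a modest rise in the number, at the edge of the scatter, going from compound 2 to compound 3, as a 1.9-fold higher number from compound 2 to compound 3 (0.27 log units; within the scatter). Compound 3 is therefore estimated at 8000 nM in this assay, with a range from 2000 nM to 40000 nM.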

Compound 3, half-maximal effective concentration: 6460 nM
Beside the measured number, compound 3's estimate is 1.2-fold (0.09 log units) above it; measured number inside the range.
By their numbers in this assay, from the lowest: compounds 2 and 3 (each within the scatter of the next); then compound 1.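

For the compounds shown here, compound 2 and compound 3 form the first pair that isolates a single change, ethyl in place of cyclopentyl on an oxygen on an unsaturated carbon, and in this assay the step is a 1.5-fold higher number from compound 2 to compound 3 (0.18 log units; within the scatter). At this position, therefore, the five-membered carbon ring can be exchanged for an open chain of 2 carbons with no difference that stands clear of the scatter, so neither the ring nor the 5 carbons of cyclopentyl are shown to matter for this read-out in this pair. No measured evidence bears on why this exchange leaves the number within the scatter.

This single pair does not tell whether a longer chain such as n-hexyl, a benzyl group or a chain ending in an amine on the same oxygen would also stay within the scatter. Going by these compounds alone, it also leaves unresolved which of the several differences in compound 1 goes with its value of 1810000 nM, since no single step connects compound 1 to compound 2 or compound 3.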